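From thiophen-3-yl to 1-benzofuran-2-yl on the shared core

This account rests on a few compounds, and the source may have more. Where it says the series, first, only, none or still open, it means among the compounds named here.

In an ADME assay on Huh-7 cells (Homo sapiens) for cytotoxicity (on this read-out higher numbers stand for lower toxicity in this test and lower numbers for higher toxicity in this test), compound 1 (`C[C@]1(CO)O[C@@H](n2cc(-c3ccco3)c3c(N)ncnc32)[C@H](O)[C@@H]1O`) gives > 44000 nM as a limit of the assay and not a number. Compound 2 (`C[C@]1(CO)O[C@@H](n2cc(-c3ccsc3)c3c(N)ncnc32)[C@H](O)[C@@H]1O`) gives > 44000 nM as a limit too. Compound 2 therefore has no number to its name, and its standing is the limit of > 44000 nM in this assay, at which 2 of the 2 values shown sit, in the notes. Within the data shown here, the one measured step is a step that the two limits leave unreadable from compound 1 to compound 2 and offers no size to carry forward. Compound 3 (`C[C@]1(CO)O[C@@H](n2cc(-c3cc4ccccc4o3)c3c(N)ncnc32)[C@H](O)[C@@H]1O`) has 1-benzofuran-2-yl in place of thiophen-3-yl on an aromatic carbon on the same core. Among the measured compounds shown here, no measured step covers this change, so the expectation in this assay is no step beyond the scatter, with a number under the limit left open. The expected move is an at least 1.1-fold lower number from compound 2 to compound 3 (0.06 log units; that floor lies within the scatter) on this estimate. Compound 3 is expected at 38000 nM with an estimated range of 15000 nM to 44000 nM in this assay for now.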

Compound 3, half-maximal cytotoxic concentration: 31100 nM
Estimate against measurement, compound 3: 1.2-fold (0.09 log units) above; the range from low to high includes it.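

In this assay, among these compounds, compound 3 is the first compound to give a number rather than a limit, showing that a reading under the limit is possible at this aromatic carbon of the shared core with 1-benzofuran-2-yl, which brings a six-membered aromatic ring of carbon only. Against the two earlier groups, the change gives an at least 1.4-fold lower number from compound 2 to compound 3 (0.15 log units; that floor lies within the scatter) and an at least 1.4-fold lower number from compound 1 to compound 3 (0.15 log units; that floor lies within the scatter), and each of these is a floor rather than a full size. The step from compound 1 to compound 2 cannot be read, so furan-2-yl and thiophen-3-yl remain unordered, and most of the picture here is still a limit: the limit of > 44000 nM in this assay, at which 2 of the 3 values shown sit.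

On these data alone, how far compound 1 and compound 2 actually lie from compound 3 stays open. Also open, as far as these compounds go, is whether a plain phenyl ring, or a ring carrying an amine, would give a number at this position.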